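This account rests on a few compounds, and the source may have more. Where it says the series, first, only, none or still open, it means among the compounds named here.

Compound 3 `C=CC(=O)NCc1coc(-c2c(N)ncnc2Nc2ccc(Oc3cccc(F)c3)c(Cl)c2)n1` carries a 3-fluorophenyl on an oxygen on an aromatic ring of the shared core. In an in vitro ADME assay on microsomes from liver (Canis lupus familiaris) for metabolic stability, tested at 5 uM (on this read-out lower numbers stand for a shorter-lived compound and higher numbers for a longer-lived compound), compound 3 gives > 1.66 h, which is a limit of the assay and not a number. Compound 1 `C=CC(=O)NCc1coc(-c2c(N)ncnc2Nc2ccc(OCc3cccc(F)c3)c(Cl)c2)n1` carries a 3-fluorobenzyl at the same oxygen; in this assay compound 1 gives > 1.66 h, also a limit. Compound 2 `C=CC(=O)NCc1coc(-c2c(N)ncnc2Nc2ccc(Oc3ccccc3)c(Cl)c2)n1` carries a plain phenyl there; in this assay compound 2 gives > 1.66 h, again a limit. Every value shown so far therefore sits at the limit of > 1.66 h in this assay, at which 3 of the 3 values shown sit. The steps between them are accordingly unreadable: a step that the two limits leave unreadable from compound 1 to compound 2, a step that the two limits leave unreadable from compound 1 to compound 3 and a step that the two limits leave unreadable from compound 2 to compound 3.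

Compound 4 `C=CC(=O)NCc1coc(-c2c(N)ncnc2Nc2ccc(Oc3ccc(F)cc3)c(Cl)c2)n1` differs from compound 3 in that (4-fluorophenyl in place of 3-fluorophenyl on an oxygen on an aromatic ring). The step closest to this change is the one that adds fluoro in place of hydrogen on an aromatic carbon, a step that the two limits leave unreadable from compound 2 to compound 3, whose size could not be read; the steps that exchange the whole group on the oxygen were likewise unreadable. Within the data shown here, nothing among the measured compounds suggests that the half-life would fall below the limit once the fluorine sits elsewhere on the phenyl.

Compound 4 is therefore expected to give 2.5 h in this assay, within 1.2 h to 6 h, most probably again reported as a limit. The step this estimate means, a step that the limit leaves unreadable from compound 3 to compound 4, is expected to stay within the usual scatter.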

Compound 4, half-life: > 1.66 h
Compound 4 was reported as a limit; the forecaster's own chance of this, stated with the estimate: 80%; the middle value lies beyond the limit too.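

No new step can be read, since the steps joining compound 4 to compound 1, compound 2 and compound 3 in this assay all rest on limits and not on numbers: the limit of > 1.66 h in this assay, at which 4 of the 4 values shown sit. The compounds shown leave open how far each half-life lies beyond that limit, and whether 3-fluorophenyl, 4-fluorophenyl, phenyl and 3-fluorobenzyl differ at all.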